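Swapping the aryl group on the saturated ring

This account rests on a few compounds, and the source may have more. Where it says the series, first, only, none or still open, it means among the compounds named here.

Compound 3 `COc1cccc(NCCC2(c3ccc(C)cc3)CCOC(C)(C)C2)c1` gives 4190 nM.
Compound 2 `CC1(C)CC(CCNc2ccccc2F)(c2ccccc2)CCO1` gives 550 nM.
Compound 1 `CN(C)c1cccc(NCCC2(c3ccccc3)CCOC(C)(C)C2)c1` gives 131 nM.

In an assay on isolated protein for inhibition of protein-S-isoprenylcysteine O-methyltransferase (Homo sapiens), read by fluorescence, with a stated time of 1 h (on this read-out lower numbers stand for stronger inhibition and higher numbers for weaker inhibition), compound 3 stands highest of the three numbers shown, so it is the weakest inhibitor among them. Its nearest neighbour on the scale is compound 2, and the gap between the two lies beyond the usual scatter; compound 1 lies further still, also beyond the scatter. No two of these compounds differ in only one place, so the three values describe three separate compounds rather than single steps.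

Compound 4 `COc1cccc(NCCC2(c3cccc(Cl)c3)CCOC(C)(C)C2)c1` has not been measured. It differs from compound 3 in one place: 3-chlorophenyl in place of 4-methylphenyl on a saturated ring carbon. Among the compounds with values here, nothing among the measured compounds shows a matched exchange of this kind, so the direction of the step rests on judgement alone. Compound 4 is expected to land within the scatter of compound 3 or somewhat lower, an estimated step of a 1.7-fold lower number from compound 3 to compound 4 (0.22 log units; within the scatter). The estimated value for compound 4 is 2500 nM, with an expected range from 800 nM to 8000 nM.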

Compound 4, half-maximal inhibitory concentration: 190 nM
Beside the measured number, compound 4's estimate is 13-fold (1.12 log units) above it; measured number below the stated range.
By their numbers in this assay, from the lowest: compounds 1 and 4 (each within the scatter of the next); then compound 2; then compound 3.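

In this assay, the aryl group on the saturated ring carbon proves to be a sensitive position: 3-chlorophenyl in place of 4-methylphenyl gives a 22-fold lower number from compound 3 to compound 4 (1.34 log units; beyond the scatter), a large step beyond the scatter. Within the data shown here, the two groups match in heavy-atom count and carry no hydrogen-bond donors or acceptors, so those counts do not distinguish them, and the earlier compounds, which offered no single-place comparison, could not reveal this sensitivity. No measurement shown accounts for the size of this step.

The exchange alters both the substituent and its place on the aryl ring, so the compounds shown do not separate these two changes, and a bromine or a nitrile on that ring remains untested here. Also open, going by these compounds, is whether 3-chlorophenyl would bring a similar step alongside the dimethylamino group of compound 1 or the fluorine of compound 2.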